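The source may report more compounds than this note shows. Statements on the series, on what has been measured and on what is new or still open speak of the compounds shown alone.

Compound 1 `OC[C@H]1O[C@@H](n2cnc3c(NCc4cccc(Br)c4)ncnc32)[C@H](O)[C@@H]1O` gives 8000 nM here.
Compound 2 `OC[C@H]1O[C@@H](n2cnc3c(NCc4c(F)ccc(F)c4F)ncnc32)[C@H](O)[C@@H]1O` gives 13000 nM here.

Both numbers come from a functional assay on HL-60 cells (Homo sapiens) for antiproliferative activity, with a stated time of 72 h (on this read-out lower numbers stand for stronger inhibition and higher numbers for weaker inhibition), and are all that has been measured so far. Compound 2 stands within the scatter of compound 1, so neither can be ranked above the other. Compound 3 `OC[C@H]1O[C@@H](n2cnc3c(NCc4ccc(F)cc4Cl)ncnc32)[C@H](O)[C@@H]1O` has not yet been measured. It differs from compound 2 by 2-chloro-4-fluorophenyl in place of 2,3,6-trifluorophenyl on a saturated chain carbon bound to a nitrogen on an aromatic ring in the group on a saturated chain carbon bound to a nitrogen on an aromatic ring, where 2-chloro-4-fluorophenyl takes the place of 2,3,6-trifluorophenyl. Going by the values given here, the only measured step that bears on this place is a 1.6-fold higher number from compound 1 to compound 2 (0.21 log units; within the scatter) and it exchanged 3-bromophenyl for 2,3,6-trifluorophenyl. One small step is thin evidence, but it gives no reason to expect a large change in either direction. The estimated move is a 1.3-fold lower number from compound 2 to compound 3 (0.11 log units; within the scatter) and no step beyond the scatter is expected. For compound 3 the expected value is 10000 nM with an estimated range from 4000 nM to 25000 nM in this read-out.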

Compound 3, half-maximal inhibitory concentration: 9000 nM
Beside the measured number, compound 3's estimate is 1.1-fold (0.05 log units) above it; the range from low to high includes it.
By their numbers in this assay, from the lowest: compounds 1, 3 and 2 (each within the scatter of the next).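

Putting 2-chloro-4-fluorophenyl in place of 2,3,6-trifluorophenyl on a saturated chain carbon bound to a nitrogen on an aromatic ring gives a 1.4-fold lower number from compound 2 to compound 3 (0.16 log units; within the scatter) and putting it in place of 3-bromophenyl gives a 1.1-fold higher number from compound 1 to compound 3 (0.05 log units; within the scatter). In this assay, going by these compounds alone, three phenyl groups with different halogens at this place therefore all lie within the scatter of one another, which the single earlier step could not show for more than one pair. No measurement offered here explains this result.

From the compounds shown here alone, all three groups are halogen-bearing phenyl rings, so it stays open how an unsubstituted phenyl, a methoxyphenyl, a pyridine ring or a longer chain carrying the ring would read out. The compounds shown also leave open whether any change at this place can move the number beyond the scatter.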